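Working notes: carbonyl substituent exchange from compound 2 to compound 3

The source may report more compounds than this note shows. Statements on the series, on what has been measured and on what is new or still open speak of the compounds shown alone.

Both measured members of the series were run in a functional assay on MGC-803 cells (Homo sapiens) for inhibition, read by MTT assay, with a stated time of 48 h; on this read-out higher numbers stand for weaker inhibition and lower numbers for stronger inhibition. Compound 1 `COC(=O)c1cc(CNc2cc(OC)c(OC)c(OC)c2)ccc1OC` gives 49600 nM in this assay. Compound 2 `CCC/C=C/C(=O)N(Cc1ccc(OC)c(O)c1)c1cc(OC)c(OC)c(OC)c1` gives 70 nM in this assay, the lowest of the two numbers recorded; its nearest neighbour is compound 1, separated by a gap well beyond the scatter. Among the compounds with values here, no step between two measured compounds differing in one place is available, so the effect of a single change at the carbonyl has not been observed directly.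

Compound 3 `COc1ccc(CN(C(=O)C[Se]C#N)c2cc(OC)c(OC)c(OC)c2)cc1O` is not yet measured in this assay. It differs from compound 2 as follows: a group of 4 heavy atoms (2 carbon, 1 nitrogen, 1 selenium; no ring) in place of a group of 5 heavy atoms (5 carbon; no ring), on a carbonyl carbon. The amide-type nitrogen and the rest of compound 2 remain unchanged. Within the data shown here, with no comparable step on record, the expectation for compound 3 rests on compound 2 at 70 nM alone. The expected step is a 2.1-fold higher number from compound 2 to compound 3 (0.33 log units; beyond the scatter), a modest rise in the number rather than a large shift in either direction. Compound 3 is estimated at 150 nM in this assay, with a range from 30 nM to 800 nM.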

Compound 3, half-maximal inhibitory concentration: 270 nM
Compound 3: middle estimate off by 1.8-fold (0.26 log units), on the low side; low and high end bracket the measured number.
By their numbers in this assay, from the lowest: compound 2; then compound 3; then compound 1.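

Within the data shown here, the single change at the carbonyl carbon can now be read directly: in this assay, replacing pent-1-en-1-yl with the selenium-bearing nitrile group gives a 3.9-fold higher number from compound 2 to compound 3 (0.59 log units; beyond the scatter), a modest step that lies beyond the scatter. This position therefore accepts an exchange of a carbon-only group with a double bond for a group carrying selenium and a nitrile without loss of inhibition on the scale of this read-out, although pent-1-en-1-yl keeps the lower number of the pair. No measurement is available that accounts for the step or assigns it to any feature of either group.

The single step changes selenium, the nitrile and the chain together, so the compounds shown do not separate their individual contributions to the higher number. On these data alone, what a sulfur atom in place of the selenium, a pentyl chain without the double bond, or a longer chain would do at this carbonyl carbon remains open, as does whether the step would hold with any other change to the rest of compound 2.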